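This account rests on a few compounds, and the source may have more. Where it says the series, first, only, none or still open, it means among the compounds named here.

Compound 2, `Cc1cccc(Cl)c1OCCCCNC(C)CO`, was tested in a functional assay on the whole organism with Mus musculus as the target, in the maximal electroshock model (on this read-out higher numbers stand for an effect only at larger amounts of compound and lower numbers for an effect already at smaller amounts), where compound 2 gives 19.1 mg/kg. Compound 1, `Cc1cccc(C)c1OCCCCNCC(C)O`, gives 27.1 mg/kg in this assay; the gap between these two numbers lies within the usual scatter of such measurements. Compound 3, `Cc1cccc(Cl)c1OCCCCN[C@H]1CC[C@H](O)CC1`, differs from compound 2 in one place: 4-hydroxycyclohexyl in place of 1-(hydroxymethyl)ethyl on an amine nitrogen. Going by the values given here, no measured pair shows a step of this kind, so the expectation rests on compound 2 alone. A small step is expected, a 1.3-fold lower number from compound 2 to compound 3 (0.10 log units; within the scatter), not clearly beyond the scatter in either direction. Compound 3 is therefore estimated at 15 mg/kg, with a range from 6 mg/kg to 40 mg/kg.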

Compound 3, dose for half-maximal effect: 41.1 mg/kg
Estimate against measurement, compound 3: 2.7-fold (0.44 log units) below; the whole stated range lies below it.
By their numbers in this assay, from the lowest: compounds 2, 1 and 3 (each within the scatter of the next, the first and the last beyond it).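

Putting 4-hydroxycyclohexyl in place of 1-(hydroxymethyl)ethyl on an amine nitrogen gives a 2.2-fold higher number from compound 2 to compound 3 (0.33 log units; beyond the scatter) in this assay and so calls for a larger amount of compound to reach the effect. The group on this nitrogen therefore does matter, although the change is modest and the effect remains with the six-membered ring in place. Nothing available explains this shift. From the compounds shown here alone, it remains open whether the ring itself or its hydroxyl accounts for the step. A plain cyclohexyl or a longer hydroxyalkyl chain on this nitrogen would help separate the two.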